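Swapping the Thiadiazole for an Oxadiazole on the Thioether

The compounds below may be only part of what the source reports. "The series", "measured", "known", "first", "only" and "open" are said of these compounds alone.

Of the compounds shown here, three of this set have been tested in a functional assay on SW480 cells (Homo sapiens) for cytotoxicity, read by MTT assay, with a stated time of 72 h; a lower number here means a stronger inhibitor, a higher number a weaker inhibitor. Compound 1 `Cc1nnc(SCc2coc3ccccc3c2=O)o1` gives 790 nM. Compound 2 `Cc1ccc2oc(CSc3nnc(N)s3)cc(=O)c2c1` reaches only a limit, > 25000 nM, and not a number. Compound 3 `Nc1nnc(SCc2coc3ccccc3c2=O)s1` likewise stops at a limit, > 25000 nM. That two of the three values sit at the limit is itself a point to note, since the limit of > 25000 nM in this assay, at which 2 of the 3 values shown sit, marks the edge of what this assay reports.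

Within the data shown here, the one counted step is from compound 3 to compound 1, where 5-methyl-1,3,4-oxadiazol-2-yl in place of 5-amino-1,3,4-thiadiazol-2-yl on a sulfur produced an at least 31-fold lower number from compound 3 to compound 1 (1.50 log units; beyond the scatter). How the core of compound 2 differs from that of compound 3 is not broken down here. Among the measured compounds shown here, compound 4 `Cc1ccc2oc(CSc3nnc(C)o3)cc(=O)c2c1` is not yet measured; it arises from compound 2 by 5-methyl-1,3,4-oxadiazol-2-yl in place of 5-amino-1,3,4-thiadiazol-2-yl on a sulfur, and since the place is the same word for word, this is the same change as the one from compound 3 to compound 1.

Because an at least 31-fold lower number from compound 3 to compound 1 (1.50 log units; beyond the scatter) was seen, a step of similar direction is expected here, and the estimated step is an at least 25-fold lower number from compound 2 to compound 4 (1.39 log units; beyond the scatter). Compound 2 gives only a limit, so the absolute level is uncertain. Compound 4 is expected to give around 1000 nM, with the estimate running from 300 nM to 5000 nM, close to what compound 1 shows.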

Compound 4, half-maximal inhibitory concentration: > 25000 nM
Compound 4: only a limit was reported; the forecaster's own chance of this, stated with the estimate: 15%; at least 25-fold (1.39 log units) between middle value and limit.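

In this assay compound 4 also stops at a limit, > 25000 nM, and not a number. Among these compounds, compound 2 stands at a limit too, so no step between compound 2 and compound 4 can be read: the limit of > 25000 nM in this assay, at which 3 of the 4 values shown sit. The compounds shown leave open whether 5-methyl-1,3,4-oxadiazol-2-yl in place of 5-amino-1,3,4-thiadiazol-2-yl changes anything on the core of compound 2.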